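The compounds below may be only part of what the source reports. "The series", "measured", "known", "first", "only" and "open" are said of these compounds alone.

Compound 1 `COc1cc(-c2ccnc3cc(-c4ccc(Cl)cc4)nn23)cc(OC)c1OC`: 2320 nM
Compound 2 `COc1cc(-c2ccnc3cc(-c4ccc(N(C)C)cc4)nn23)cc(OC)c1OC`: 44 nM

In a functional assay on MCF7 cells (Homo sapiens) for inhibition, read by CCK-8 assay, with a stated time of 48 h (a higher number here means a weaker inhibitor, a lower number a stronger inhibitor), compound 2 has the lower of the two numbers, at 44 nM. Compound 3 `CCOC(=O)c1ccc(-c2cc3nccc(-c4cc(OC)c(OC)c(OC)c4)n3n2)cc1` carries ethoxycarbonyl in place of dimethylamino on an aromatic carbon. Going by the values given here, the one measured step bearing on this change, at the same place, is a 53-fold lower number from compound 1 to compound 2 (1.72 log units; beyond the scatter), and it is large. Among the compounds with values here, compound 3 gives up the dimethylamino group, and no ethoxycarbonyl compound has been measured, so a large step to a higher number is expected in this assay. The estimated step is a 34-fold higher number from compound 2 to compound 3 (1.53 log units; beyond the scatter). For compound 3 the expected value is 1500 nM, within an estimated range of 300 nM to 6000 nM.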

Compound 3, half-maximal inhibitory concentration: > 10000 nM
Compound 3 was reported as a limit; the forecaster's own chance of this, stated with the estimate: 5%; middle value at least 6.6-fold (0.82 log units) away from the limit.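

Compound 3 stands as a limit of this assay, not as a number: the limit of > 10000 nM in this assay, at which 1 of the 3 values shown sits. At this place on the aromatic ring, ethoxycarbonyl in place of dimethylamino gives an at least 220-fold higher number from compound 2 to compound 3 (2.35 log units; beyond the scatter). Ethoxycarbonyl in place of chloro gives an at least 4.3-fold higher number from compound 1 to compound 3 (0.63 log units; beyond the scatter), so chloro does not mark the weak end at this position, and the three groups fall in the order dimethylamino, chloro, ethoxycarbonyl.

On these data alone, how far compound 3 lies past its limit stays open. Also open, as far as these compounds go, is whether a primary amine, a pyrrolidine or a methoxy group at this place would keep the low number of compound 2.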